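The compounds below may be only part of what the source reports. "The series", "measured", "known", "first", "only" and "open" are said of these compounds alone.

Of the compounds shown here, three have been tested in an ADME assay on L02 cells (Homo sapiens) for cytotoxicity, read by MTT assay, with a stated time of 24 h; on this read-out lower numbers stand for stronger inhibition and higher numbers for weaker inhibition. In this assay compound 1 `CC(=O)Nc1ccc(S(=O)(=O)N2C/C(=C\c3cccnc3)C(=O)/C(=C/c3ccccc3F)C2)cc1` gives 15600 nM, and compound 2 `O=C1/C(=C/c2ccncc2)CN(S(=O)(=O)c2ccc(F)cc2)C/C1=C\c1ccccc1F` gives 15600 nM.

Compound 3 `N#Cc1ccc(S(=O)(=O)N2C/C(=C\c3ccncc3)C(=O)/C(=C/c3ccccc3F)C2)cc1` gives > 20000 nM, which is a limit of the assay and not a number. As far as these compounds go, its place on the scale is therefore known only as a limit, so any comparison with it is open on one side.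

Compound 4 `CC(=O)Nc1ccc(S(=O)(=O)N2C/C(=C\c3ccncc3)C(=O)/C(=C/c3ccccc3F)C2)cc1` has not yet been measured. It differs from compound 3 by a single change, acetamido in place of cyano on an aromatic carbon, para to a large group: acetamido in place of cyano on an aromatic carbon.

Among the measured compounds shown here, one measured step touches the same place, and it is an at least 1.2-fold higher number from compound 2 to compound 3 (0.10 log units; that floor lies within the scatter). From the compounds shown here alone, there, cyano replaced fluoro, so compound 3 is again the cyano member, and the true size of that step remains unknown. Compound 1, which also carries acetamido, gives 15600 nM, a real number rather than a limit.

On this thin evidence, no step beyond the scatter is expected in this assay, although any shift would more likely be towards a lower number than a higher one. The expected change is an at least 1.2-fold lower number from compound 3 to compound 4 (0.09 log units; that floor lies within the scatter). For compound 4 the estimated value is 16000 nM, with an expected range from 9000 nM to 25000 nM.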

Compound 4, half-maximal inhibitory concentration: 12300 nM
For compound 4 the middle estimate is 1.3-fold (0.11 log units) above the measured one, and the stated range covers the measured number.
By their numbers in this assay, from the lowest: compounds 4, 1 and 2 (each within the scatter of the next). At a limit, above all of these: compound 3.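

In this assay, as far as these compounds go, acetamido in place of cyano on this aromatic carbon gives an at least 1.6-fold lower number from compound 3 to compound 4 (0.21 log units; that floor lies within the scatter), and the true size of that step stays unknown because compound 3 stands at a limit of the assay and not at a number: the limit of > 20000 nM in this assay, at which 1 of the 4 values shown sits. The new compound also shows that acetamido and fluoro at this place cannot be told apart here, with a 1.3-fold lower number from compound 2 to compound 4 (0.10 log units; within the scatter). Nor can pyridin-4-yl and pyridin-3-yl be told apart on the double-bonded chain carbon when acetamido is present, with a 1.3-fold lower number from compound 1 to compound 4 (0.10 log units; within the scatter).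

The compounds shown leave open whether cyano truly differs from acetamido and fluoro at this place, since only a number for a cyano compound could settle the size of that gap. They also leave open how this position responds to groups not among them, such as an amine, a carboxylic acid or a longer chain on the nitrogen of the acetamido group, and whether any such group would produce a step beyond the scatter in this assay.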